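The source may report more compounds than this note shows. Statements on the series, on what has been measured and on what is new or still open speak of the compounds shown alone.

Compound 1 `NC(=O)N(O)CC1=Cc2cc(OCc3ccc(C(F)(F)F)cc3)ccc2OC1` gives 430 nM in an assay (Cavia porcellus) for inhibition of Polyunsaturated fatty acid 5-lipoxygenase (Homo sapiens); a higher number here means a weaker inhibitor, a lower number a stronger inhibitor.
Compound 2 `CCCCCCOc1ccc2c(c1)C=C(CN(O)C(N)=O)CO2` gives 280 nM in this assay.
Compound 3 `NC(=S)N(O)CC1=Cc2cc(Oc3ccccc3)ccc2OC1` gives 180 nM in this assay.

Of the three measured compounds, compound 3 has the lowest number in this assay. Its gap to compound 2 lies within the scatter, so the two cannot be ranked against each other; its gap to compound 1 lies beyond the scatter.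

Compound 4 `O=C(NCc1ccccc1)N(O)CC1=Cc2cc(Oc3ccccc3)ccc2OC1` has not been measured. It differs from compound 3 in one place: a group of 10 heavy atoms (8 carbon, 1 nitrogen, 1 oxygen; one six-membered aromatic ring of carbon only) in place of a group of 3 heavy atoms (1 carbon, 1 nitrogen, 1 sulfur; no ring), on an amine nitrogen. Within the data shown here, no pair of measured compounds shows such a change, so no measured step can be borrowed for it; the series gives no direct guide to how this assay responds at this nitrogen.

On that basis the writer expects a modest rise in the number, a 2.5-fold higher number from compound 3 to compound 4 (0.40 log units; beyond the scatter), and estimates compound 4 at 450 nM in this assay, with a range from 130 nM to 1600 nM.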

Compound 4, half-maximal inhibitory concentration: 440 nM
Beside the measured number, compound 4's estimate is 1.0-fold (0.01 log units) above it, and the stated range covers the measured number.
By their numbers in this assay, from the lowest: compounds 3, 2, 1 and 4 (each within the scatter of the next, the first and the last beyond it).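

A step of a 2.4-fold higher number from compound 3 to compound 4 (0.39 log units; beyond the scatter) in this assay shows that the amine nitrogen can carry benzylcarbamoyl, a group of 10 heavy atoms with a six-membered aromatic ring, in place of the group of 3 heavy atoms at only a modest cost. The two groups have the same count of 1 hydrogen-bond donor and 1 hydrogen-bond acceptor, so the step does not come with a change in those counts. Nothing measured on these compounds accounts for the rise.

The step swaps sulfur for oxygen and adds the benzyl group at once, so the compounds shown cannot say which of the two carries it. A methylcarbamoyl group on the same nitrogen, holding the oxygen without the ring, would begin to separate them, and a longer chain such as phenethylcarbamoyl would show whether the number keeps rising with size.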